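The compounds below may be only part of what the source reports. "The series", "measured", "known", "first", "only" and "open" are said of these compounds alone.

Measured so far:
- compound 1, `Oc1cc(C(F)(F)F)ccc1-c1nc(-c2ccccc2O)n(-c2ccc(OC(F)(F)F)cc2)n1`: 65.5%
- compound 2, `Oc1cc(C(F)(F)F)ccc1-c1nc(-c2ccccc2O)n(-c2ccccc2F)n1`: 63.4%

In a functional assay on PC-12 cells (Rattus norvegicus) for cytotoxicity, read by MTT assay, with stated times of 2 h and 24 h, tested at 1 uM (on this read-out lower numbers stand for a weaker effect and higher numbers for a stronger effect at the one concentration tested), compound 1 gives 65.5% and compound 2 gives 63.4%. Going by the values given here, compound 2 is one of only two measured compounds, and the single step of a number 2.1 percentage points lower from compound 1 to compound 2 (within the scatter) lies within the scatter, so on these numbers the two cannot be told apart. Compound 3, `Oc1cc(C(F)(F)F)ccc1-c1nc(-c2ccccc2O)n(-c2ccccc2Cl)n1`, differs from compound 2 in one place: chloro in place of fluoro on an aromatic carbon. Among the compounds with values here, no measured step touches this exact change; the only step available, from compound 1 to compound 2, swapped a much larger part of the same group on the aromatic nitrogen and still moved the read-out no further than the scatter. Exchanging one halogen for another at the same spot is a smaller change than that, so the expected step in this assay is a number 0.4 percentage points lower from compound 2 to compound 3 (within the scatter), meaning no shift beyond the scatter in either direction. Compound 3 is therefore expected to give about 63% in this assay, with a likely range from 50% to 76%.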

Compound 3, a percentage reported as activity, at one concentration (the size of the read-out at that concentration, not a potency): 70.1%
Estimate against measurement, compound 3: 7.1 percentage points below; the range from low to high includes it.
By their numbers in this assay, from the lowest: compounds 2, 1 and 3 (each within the scatter of the next).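

In this assay, going by these compounds alone, the step 2-fluorophenyl to 2-chlorophenyl, with chloro in place of fluoro on an aromatic carbon ortho to a large group, gives a number 6.7 percentage points higher from compound 2 to compound 3 (within the scatter), which is the only reading here of a change to a single substituent at this spot rather than of a whole group on the aromatic nitrogen. The wider exchange of 2-chlorophenyl in place of 4-(trifluoromethoxy)phenyl on that nitrogen gives a number 4.6 percentage points higher from compound 1 to compound 3 (within the scatter), so the three groups shown there cannot be told apart on this read-out, and neither halogen at this spot can be ranked above the other.

Going by these compounds, what remains open is whether a group of another kind in place of the chloro, such as an amine, a carboxylic acid or a longer chain like propyl, would shift the number beyond the usual scatter, since both groups compared at this spot are single halogen atoms. Nor can anything be said about why the three numbers lie so close together, as no separate measurement bears on these steps.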